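Hydrazide Analogues on Breast Cancer Cells: A Cautious Look

This account rests on a few compounds, and the source may have more. Where it says the series, first, only, none or still open, it means among the compounds named here.

Measured so far:
compound 1, `CC(C)=CCC/C(C)=C/COc1ccc(C2CC2C(=O)NNC(=O)c2ccncc2)cc1`: "not determined" (no result reported)
compound 2, `O=C(NNC(=O)C1CC1c1ccc(OCC(F)(F)F)cc1)c1ccncc1`: 34000 nM
compound 3, `COc1ccc(C2CC2C(=O)NNC(=O)c2ccncc2)cc1`: "not determined" (no result reported)

Three compounds sharing one core were examined in a functional assay on MCF7 cells (Homo sapiens) for inhibition, read by MTT assay, with a stated time of 72 h; a higher number here means a weaker inhibitor, a lower number a stronger inhibitor. Compound 1 stands without any single number in this assay, and compound 3 is a further entry in the same position, so neither can be placed on the scale. Only compound 2 carries a number, and in this assay compound 2 gives 34000 nM, which marks it as a weak inhibitor.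

Compound 4, `CC(C)=CCC/C(C)=C/COc1ccc(C2CC2C(=O)NNc2nncc3ccccc23)cc1`, is the next compound to be tested. It differs from compound 1 in one place: a group of 10 heavy atoms (8 carbon, 2 nitrogen; one six-membered aromatic ring of carbon only, one six-membered aromatic ring with 2 hetero atoms) in place of a group of 8 heavy atoms (6 carbon, 1 nitrogen, 1 oxygen; one six-membered aromatic ring with 1 hetero atom), on an amine nitrogen. The rest of the molecule, including the long chain on the ether oxygen, is unchanged.

Among the measured compounds shown here, with no number for compound 1, the step to compound 4 in this assay cannot be measured from the present data; the only anchor is compound 2. The expectation is a step of modest size, most likely within the usual scatter or, at best, a small gain in potency. Compound 4 is therefore estimated to give 25000 nM in this assay, within a range from 5000 nM to 100000 nM.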

Compound 4, half-maximal inhibitory concentration: 23000 nM
Estimate against measurement, compound 4: 1.1-fold (0.04 log units) above; the measured number falls inside the stated range.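

In this assay, among the compounds shown here, compound 4 gives 23000 nM while compound 1 has no single number, so no step from compound 1 to compound 4 can be read. The compounds shown leave open whether replacing the (pyridin-4-yl)carbonyl group on the amine nitrogen changes inhibition at all. No measurement shown here offers an explanation for the value of compound 4.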